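Hydroxy in Place of Methylsulfanyl on the Shared Core

This account rests on a few compounds, and the source may have more. Where it says the series, first, only, none or still open, it means among the compounds named here.

Compound 1 `CSc1nnc(-c2ccccc2)c2cncn12` gives > 48000 nM in a functional assay for inhibition, with Homo sapiens as the target (a lower number here means a stronger inhibitor, a higher number a weaker inhibitor), which is a limit of the assay and not a number.
Compound 2 `CCc1ncn2c(S)nncc12` gives > 48000 nM in this assay, again a limit of the assay.
Compound 3 `CCCc1nc(Br)c2c(Br)nnc(O)n12` gives 48000 nM in this assay.

Compound 1 therefore stands at the edge of what this assay can report, with no number of its own. Among the compounds with values here, this is the situation described by the limit of > 48000 nM in this assay, at which 2 of the 3 values shown sit, so the three measured compounds give no ordering among themselves and no step between any two of them can be sized.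

Compound 4 `Oc1nnc(-c2ccccc2)c2cncn12` has not yet been measured. It differs from compound 1 by hydroxy in place of methylsulfanyl on an aromatic carbon. Within the data shown here, with no measured step to lean on, the expectation for compound 4 in this assay is simply that it remains near where compound 1 sits, most likely again as a limit rather than a number. The estimate for compound 4 is 48000 nM, with a range from 16000 nM to 150000 nM. The expected step of a number no higher from compound 1 to compound 4 (the limit leaves the size open) is therefore none beyond the scatter.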

Compound 4, half-maximal inhibitory concentration: 19000 nM
The estimate for compound 4 lay 2.5-fold (0.40 log units) above the measured number; measured number inside the range.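

Hydroxy in place of methylsulfanyl on an aromatic carbon gives an at least 2.5-fold lower number from compound 1 to compound 4 (0.40 log units; beyond the scatter) in this assay. Within the data shown here, this is the first sign that this position of the shared core, between two ring nitrogen atoms, can respond to a change of group, and compound 4 gives 19000 nM, a real number rather than a limit. Compound 1 has only a limit of the assay, so the step has a lower end but no full size: the limit of > 48000 nM in this assay, at which 2 of the 4 values shown sit.

Among these compounds, the single pair cannot show whether the hydrogen-bond donor that hydroxy brings matters, or whether simply losing methylsulfanyl is enough. A methoxy group or an amine on the same carbon would help to separate these two readings, and a single pair gives no guide to how either would behave.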